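The compounds below may be only part of what the source reports. "The series", "measured", "known", "first", "only" and "open" are said of these compounds alone.

Compound 3 `CN(C)CCN(C)c1ccc(Cn2c(=O)[nH]c3c(N)nc(C(F)(F)F)cc32)cn1` stands highest of the two plain numbers in an in vitro ADME assay on microsomes from liver (Homo sapiens) for pharmacokinetics (on this read-out higher numbers stand for fast clearance and lower numbers for slow clearance), where compound 3 gives 16 mL.min-1.g-1. Compound 2 `Nc1nc(C(F)(F)F)cc2c1[nH]c(=O)n2Cc1ccc(NCCN2CCCC2)nc1` gives 8.5 mL.min-1.g-1 in this assay, and the step of a 1.9-fold higher number from compound 2 to compound 3 (0.27 log units; within the scatter). From the compounds shown here alone, compound 1 `CN(C)CCN1CCN(c2ccc(Cn3c(=O)[nH]c4c(N)nc(C(F)(F)F)cc43)cn2)CC1` reaches only a limit of this assay, < 8 mL.min-1.g-1, so its true number is unknown. The steps of an at least 1.0-fold higher number from compound 1 to compound 2 (0.02 log units; that floor lies within the scatter) and an at least 2.0-fold higher number from compound 1 to compound 3 (0.30 log units; that floor lies within the scatter) are therefore floors rather than exact sizes.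

Compound 4 `CN1CCN(c2ccc(Cn3c(=O)[nH]c4c(N)nc(C(F)(F)F)cc43)cn2)CC1` differs from compound 3 in one place: 4-methylpiperazin-1-yl in place of (2-(dimethylamino)ethyl)(methyl)amino on an aromatic carbon. This roughly reverses the move from compound 1 to compound 3, in which the open chain replaced a piperazine ring. A lower number is therefore expected, and the step of a 2.0-fold lower number from compound 3 to compound 4 (0.30 log units; within the scatter) is the estimate. Compound 4 is expected to give about 8 mL.min-1.g-1, somewhere between 4 mL.min-1.g-1 and 16 mL.min-1.g-1, possibly again only as a limit.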

Compound 4, intrinsic clearance in microsomes: 30 mL.min-1.g-1
Estimate against measurement, compound 4: 3.8-fold (0.57 log units) below, outside the stated range (above it).
By their numbers in this assay, from the lowest: compounds 2, 3 and 4 (each within the scatter of the next, the first and the last beyond it). At a limit, below all of these: compound 1.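

In this assay, a piperazine ring does not by itself keep the number low: the step is a 1.9-fold higher number from compound 3 to compound 4 (0.27 log units; within the scatter), while the change from the pyrrolidine chain gives a 3.5-fold higher number from compound 2 to compound 4 (0.55 log units; beyond the scatter). What hangs on the ring counts more, as losing (dimethylamino)methyl from its side chain gives an at least 3.7-fold higher number from compound 1 to compound 4 (0.57 log units; beyond the scatter). Compound 1 stands at a limit, so this step is only a floor: the limit of < 8 mL.min-1.g-1 in this assay, at which 1 of the 4 values shown sits.

From the compounds shown here alone, whether a hydroxyl group could replace the dimethylamino group on that side chain and still hold the number down stays open. So does the true number of compound 1.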